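A few compounds are considered here, and "the series" means these few. Any claim that something is new, unique, unknown or untested is made for them only; others in the source may bear on it.

Measured in a functional assay on A549 cells (Homo sapiens) for antiproliferative activity, read by MTT assay, with a stated time of 72 h; a lower number here means a stronger inhibitor, a higher number a weaker inhibitor: compound 1 `CNC(=O)c1cc(Oc2ccc(NC(=O)c3cc4cccnc4n(-c4ccc(C(F)(F)F)cc4Cl)c3=O)cc2)ccn1` gives 2090 nM; compound 2 `CCNC(=O)c1cc(Oc2ccc(NC(=O)c3cc4cccnc4n(-c4ccccc4)c3=O)cc2)ccn1` gives 160 nM; compound 3 `CCNC(=O)c1cc(Oc2ccc(NC(=O)c3cc4cccnc4n(-c4ccc(Br)cc4)c3=O)cc2)ccn1` gives 910 nM.

Compound 3 stands second highest of the three numbers, between compound 2 and compound 1. Among the measured compounds shown here, the one measured step on the aromatic nitrogen, a 5.7-fold higher number from compound 2 to compound 3 (0.75 log units; beyond the scatter), went upward beyond the scatter. Compound 4 `CCNC(=O)c1cc(Oc2ccc(NC(=O)c3cc4cccnc4n(-c4ccc(C(F)(F)F)cc4Cl)c3=O)cc2)ccn1` carries 2-chloro-4-(trifluoromethyl)phenyl in place of 4-bromophenyl on an aromatic nitrogen. For the measured compounds named here, no measured pair covers this exact exchange; compound 1, which carries the same 2-chloro-4-(trifluoromethyl)phenyl with a methyl amide, sits above compound 3. On that basis a further upward step is expected, a 1.8-fold higher number from compound 3 to compound 4 (0.25 log units; within the scatter), and compound 4 is estimated at 1600 nM in this assay, with a range of 600 nM to 4500 nM.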

Compound 4, half-maximal inhibitory concentration: 3290 nM
The estimate for compound 4 lay 2.1-fold (0.31 log units) below the measured number; the range from low to high includes it.
By their numbers in this assay, from the lowest: compound 2; then compound 3; then compounds 1 and 4 (each within the scatter of the next).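

On the aromatic nitrogen in this assay, 2-chloro-4-(trifluoromethyl)phenyl reads higher than both 4-bromophenyl (a 3.6-fold higher number from compound 3 to compound 4 (0.56 log units; beyond the scatter)) and phenyl (a 21-fold higher number from compound 2 to compound 4 (1.31 log units; beyond the scatter)), so among compounds 2, 3 and 4 both substituted aryl groups read above phenyl. With this aryl group held fixed, the methyl in place of hydrogen on the amide chain stays small (a 1.6-fold higher number from compound 1 to compound 4 (0.20 log units; within the scatter)). No evidence bears on the cause of these steps.

Open: how 2-chlorophenyl or 4-(trifluoromethyl)phenyl alone would read on this nitrogen, and so which part of the entering group carries the step. On these data alone, a methoxy group or an amine on the aryl ring, or a longer amide chain, also remains open.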